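The source may report more compounds than this note shows. Statements on the series, on what has been measured and on what is new or still open speak of the compounds shown alone.

Values in a functional assay on cells (T-cell line, Homo sapiens) for inhibition; on this read-out higher numbers stand for weaker inhibition and lower numbers for stronger inhibition:

Compound 1 `COc1ccc(CCCN2CCC(CNC(c3ccccc3)c3ccccc3)CC2)cc1`: 2800 nM
Compound 2 `COc1ccc(CCCN2CCC(COC(c3ccc(Br)cc3)c3ccc(Br)cc3)CC2)cc1`: 3200 nM
Compound 3 `CN1CCC(COC(c2ccccc2)c2ccccc2)CC1`: > 20000 nM, a limit of the assay rather than a number.

Compound 1 and compound 2 give numbers that sit within the usual scatter of each other, so no order between them is read. Compound 3 stands apart in that it gives only a limit, (the limit of > 20000 nM in this assay, at which 1 of the 3 values shown sits), and no number; of the three values shown, it is the one that rests there. For the measured compounds named here, compound 3 carries a methyl on the ring amine nitrogen where compound 1 and compound 2 carry a longer chain ending in an aryl, and only those two give measured numbers; no step between these compounds is computed, so only the values themselves are compared.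

Compound 4 `CCCCCN1CCC(COC(c2ccccc2)c2ccccc2)CC1` is not yet measured in this assay. Relative to compound 3 the change is butyl in place of hydrogen on a saturated chain carbon bound to an amine nitrogen in a ring. With the chain on the ring nitrogen lengthened toward what compound 1 and compound 2 carry, a step toward stronger inhibition is expected, though a measured number is not certain. The step from compound 3 to compound 4 is estimated as an at least 2.2-fold lower number from compound 3 to compound 4 (0.34 log units; beyond the scatter). For compound 4 the estimate in this assay is 9000 nM, with a range from 2500 nM to 30000 nM.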

Compound 4, half-maximal inhibitory concentration: 10800 nM
Beside the measured number, compound 4's estimate is 1.2-fold (0.08 log units) below it, and the stated range covers the measured number.
By their numbers in this assay, from the lowest: compounds 1 and 2 (each within the scatter of the next); then compound 4. At a limit, above all of these: compound 3.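

For the compounds shown here, at the ring amine nitrogen, read as methyl to pentyl, butyl in place of hydrogen on a saturated chain carbon bound to an amine nitrogen in a ring gives the first measured number on the unsubstituted ether core in this assay, where compound 4 gives 10800 nM as its value. The step is an at least 1.8-fold lower number from compound 3 to compound 4 (0.26 log units; that floor lies within the scatter), so a plain carbon chain with no ring is enough to bring a number on this core, but the printed floor alone does not establish a change beyond the scatter. Compound 3 gives > 20000 nM as a limit and not a number, so the step can be read only as a floor: the limit of > 20000 nM in this assay, at which 1 of the 4 values shown sits.

Going by these compounds, how the value moves along the chain stays open, since an ethyl, a propyl or an octyl at this place would be needed to tell whether pentyl lies on a trend or stands alone. Also open, on these data alone, is what pentyl gives on the core of compound 1 or of compound 2, and whether a hydroxyl or an amine at the end of the chain changes the picture.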